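The source may hold more compounds than are shown below. What is called first, only, known or untested is meant among the compounds shown, and "the series" means these compounds.

Measured so far:
- compound 1, `COc1cccc(CNCCCNc2ccnc3cc(-c4ccc(C(F)(F)F)cc4)ccc23)c1O` — 32000 nM
- compound 2, `COc1ccc(F)cc1CNCCCNc1ccnc2cc(Cc3ccc(C#N)cc3)ccc12` — 4200 nM
- compound 3, `FC(F)(F)c1ccc(-c2ccc3c(NCCCNCc4ccco4)ccnc3c2)cc1` — 32000 nM

In a physicochemical assay for solubility, with a stated time of 18 h, at pH 7.4 (on this read-out lower numbers stand for lower solubility and higher numbers for higher solubility), compound 1 stands level with compound 3 at the digits recorded, and these two are the highest of the three numbers. Compound 2 sits at 4200 nM, the lowest of the set, but it differs from compound 1 in two places, so its gap to compound 1 cannot be assigned to either change alone.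

Among the measured compounds shown here, the only single-place step so far, no change at the digits printed from compound 1 to compound 3 (within the scatter), concerns the group on the saturated chain carbon bound to the amine nitrogen, not the aromatic carbon of the core, so it does not bear directly on the step to compound 4.

Compound 4, `COc1cccc(CNCCCNc2ccnc3cc(Cc4ccc(F)cc4Cl)ccc23)c1O`, differs from compound 1 as follows: 2-chloro-4-fluorobenzyl in place of 4-(trifluoromethyl)phenyl on an aromatic carbon. For the measured compounds named here, no measured pair isolates this kind of change on the core. Compound 2 carries a benzyl-type group at that position and gives the lowest number, which points, weakly, toward a lower value, but the evidence is confounded. A modest drop in this assay is therefore expected, a 2.1-fold lower number from compound 1 to compound 4 (0.33 log units; beyond the scatter), with wide uncertainty. Compound 4 is estimated at 15000 nM, within a range of 4000 nM to 40000 nM.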

Compound 4, solubility: 4200 nM
Beside the measured number, compound 4's estimate is 3.6-fold (0.55 log units) above it, within the range that was stated.
By their numbers in this assay, from the lowest: compounds 2 and 4 (each within the scatter of the next); then compounds 1 and 3 (each within the scatter of the next).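

In this assay, among the compounds shown here, the aromatic carbon of the shared core that carries 4-(trifluoromethyl)phenyl in compound 1 is the first place where a single change moves the number beyond the scatter: 2-chloro-4-fluorobenzyl there gives a 7.6-fold lower number from compound 1 to compound 4 (0.88 log units; beyond the scatter). For the compounds shown here, the only earlier single-place step, no change at the digits printed from compound 1 to compound 3 (within the scatter), lies on the saturated chain carbon bound to the amine nitrogen, so on one pair each, the read-out has responded to the change on the aromatic carbon and not to the change on the chain. Nothing at hand bears on why the number falls at this position.

The step swaps a whole group, so it cannot be told whether the drop goes with the benzyl form or with the chlorine and fluorine on its ring; an unsubstituted benzyl or a 4-(trifluoromethyl)benzyl on the same aromatic carbon would separate the two. Going by these compounds, how the number responds to other groups there, such as a morpholine or a carboxylic acid, remains open, as does whether this step keeps its size with furan-2-yl in place of 2-hydroxy-3-methoxyphenyl on the chain.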